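This account rests on a few compounds, and the source may have more. Where it says the series, first, only, none or still open, it means among the compounds named here.

In an in vitro assay on FRT cells with Cystic fibrosis transmembrane conductance regulator variant F508del (Homo sapiens) as the target (a higher number here means weaker binding, a lower number tighter binding), compound 1, whose structure is `Cc1ccc(Nc2nc(-c3sc(NC(=O)c4ccc(Cl)cc4)nc3C)cs2)cc1`, gives 1100 nM. Compound 2, with structure `Cc1nc(NC(=O)c2ccc(Cl)cc2)sc1-c1csc(Nc2ccc(Cl)cc2)n1`, gives 1100 nM in this assay, so compound 2 stands level with compound 1 at the digits shown. For the measured compounds named here, the one step between these two, no change at the digits printed from compound 1 to compound 2 (within the scatter), shows that swapping a methyl for a chloro on the aromatic carbon left the reading where it was.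

Compound 3 has the structure `COc1ccc(OC)c(Nc2nc(-c3sc(NC(=O)c4ccc(Cl)cc4)nc3C)cs2)c1`. The change from compound 2 to compound 3 is 2,5-dimethoxyphenyl in place of 4-chlorophenyl on a nitrogen on an aromatic ring. Going by the values given here, this is a larger change than the one measured step: the group that leaves is the same 4-chlorophenyl that the earlier swap had produced, and the group that enters carries two methoxy groups, which no measured compound holds. The measured step bears on it only loosely, by showing that this part of compound 2 tolerated one small exchange without a change in this assay. A step of modest size, if any, is therefore expected here, with a wide range, and the estimated step of a 1.4-fold higher number from compound 2 to compound 3 (0.13 log units; within the scatter) is meant as such. For compound 3 the expected value in this assay is 1500 nM, estimated to lie between 400 nM and 6000 nM.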

Compound 3, dissociation constant: 1100 nM
The estimate for compound 3 lay 1.4-fold (0.13 log units) above the measured number; low and high end bracket the measured number.
By their numbers in this assay, from the lowest: compounds 1, 2 and 3 (each within the scatter of the next).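

Until now, only a small exchange had been tested on this nitrogen on an aromatic ring. In this assay, a much larger exchange, 2,5-dimethoxyphenyl with 10 heavy atoms and 2 hydrogen-bond acceptors in place of 4-chlorophenyl with 7 heavy atoms and 0 hydrogen-bond acceptors, gives no change at the digits printed from compound 2 to compound 3 (within the scatter) and thus no difference that can be read. Setting 2,5-dimethoxyphenyl in place of 4-methylphenyl gives the same picture, with no change at the digits printed from compound 1 to compound 3 (within the scatter), so this place accepts all three substituted phenyl groups without a readable difference, and no measurement at hand offers a reason for this.

As far as these compounds go, all three compounds carry a phenyl ring at this place, so it remains open how a saturated ring such as cyclohexyl, a longer alkyl chain, or a phenyl ring bearing a carboxylic acid or an amine would read here. From the compounds shown here alone, it also remains open whether a phenyl ring with a single methoxy group would read like the 2,5-dimethoxyphenyl compound, and the shared core is the same in all three, so these results say nothing about changes elsewhere in it.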